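A few compounds are considered here, and "the series" means these few. Any claim that something is new, unique, unknown or untested is made for them only; others in the source may bear on it.

Measured so far:
compound 1 `Cc1cc(C)nc(SCC(=O)[C@H](CC(=O)O)NC(=O)[C@@H](NC(=O)COc2cccc3ccccc23)C(C)C)n1` — in a functional assay on Jurkat cells (Homo sapiens) for inhibition (a higher number here means a weaker inhibitor, a lower number a stronger inhibitor), compound 1 gives > 200000 nM, which is a limit of the assay, not a number.
compound 2 `CC(C)[C@H](NC(=O)COc1cccc2ccccc12)C(=O)N[C@@H](CC(=O)O)C(=O)COc1ccnc(C(F)(F)F)n1` — compound 2 gives 37000 nM, the only number shown.

Compound 3 `CC(C)[C@H](NC(=O)COc1cccc2ccccc12)C(=O)N[C@@H](CC(=O)O)C(=O)COc1cc2ccccc2cn1` is compound 2 with isoquinolin-3-yl in place of 2-(trifluoromethyl)pyrimidin-4-yl on an oxygen on a saturated carbon. Among the compounds with values here, the only measured step at this place is an at least 5.4-fold lower number from compound 1 to compound 2 (0.73 log units; beyond the scatter), and it starts from a limit (the limit of > 200000 nM in this assay, at which 1 of the 2 values shown sits), so its true size is open. Exchanging the aryl group on this oxygen has so far moved the number; the direction for compound 3 is uncertain, and the expected step of a 1.4-fold higher number from compound 2 to compound 3 (0.13 log units; within the scatter) is set near no change. Compound 3 is estimated at 50000 nM, range 10000 nM to 200000 nM.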

Compound 3, half-maximal inhibitory concentration: > 200000 nM
Compound 3 gave a limit, no number (the forecaster's own chance of this, stated with the estimate: 25%); middle value at least 4.0-fold (0.60 log units) away from the limit.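

Isoquinolin-3-yl in place of 2-(trifluoromethyl)pyrimidin-4-yl on this oxygen gives an at least 5.4-fold higher number from compound 2 to compound 3 (0.73 log units; beyond the scatter), so keeping the oxygen link does not by itself preserve the measurable inhibition of compound 2. Compound 3 gives > 200000 nM, which is a limit of the assay, not a number. The step between compound 1 and compound 3 cannot be read because both values are limits: the limit of > 200000 nM in this assay, at which 2 of the 3 values shown sit.

Going by these compounds, it remains open whether the ring nitrogens or the trifluoromethyl group account for the number of compound 2. An unsubstituted pyrimidin-4-yl or a 2-methylpyrimidin-4-yl on the same oxygen would separate the two.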